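The compounds below may be only part of what the source reports. "The series", "measured", "known", "first", "only" and "open" are said of these compounds alone.

Of the compounds shown here, three built on one shared core have been tested in a functional assay on MGC-803 cells (Homo sapiens) for inhibition, read by sulforhodamine B assay; a lower number here means a stronger inhibitor, a higher number a weaker inhibitor. Compound 1 `COc1ccccc1NC1=CC(=O)c2c(nc3n2[C@H]2OC[C@@H](O)[C@H]2OC3)C1=O` gives 1670 nM in this assay. Compound 2 `CCCc1ccc(NC2=CC(=O)c3nc4n(c3C2=O)[C@H]2OC[C@@H](O)[C@H]2OC4)cc1` gives 1560 nM, and compound 3 `CCOc1ccccc1NC1=CC(=O)c2nc3n(c2C1=O)[C@H]1OC[C@@H](O)[C@H]1OC3` gives 2450 nM. On these three numbers compound 1 stands second highest, but its gaps to compound 2 and to compound 3 both fall within the scatter, so none of the three can be separated from the others. Among the measured compounds shown here, the only step between compounds that differ in a single place, a 1.6-fold higher number from compound 2 to compound 3 (0.20 log units; within the scatter), exchanges one group on the amine nitrogen and leaves the number unchanged beyond the scatter.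

Compound 4 `O=C1C(Nc2ccc(I)cc2)=CC(=O)c2c1nc1n2[C@H]2OC[C@@H](O)[C@H]2OC1` has not yet been measured. It differs from compound 1 in one place: 4-iodophenyl in place of 2-methoxyphenyl on an amine nitrogen. For the measured compounds named here, no measured pair shows exactly this exchange. The nearest guide is that single step, which also exchanges a group on the amine nitrogen and stays within the scatter, together with compound 2, which carries 4-propylphenyl on that nitrogen and gives 1560 nM. From this the step of a 1.0-fold lower number from compound 1 to compound 4 (0.02 log units; within the scatter) is expected to stay within the scatter, with no clear direction. Compound 4 is therefore estimated at 1600 nM in this assay, with a likely range from 700 nM to 3600 nM.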

Compound 4, half-maximal inhibitory concentration: 2150 nM
For compound 4 the middle estimate is 1.3-fold (0.13 log units) below the measured one, within the range that was stated.
By their numbers in this assay, from the lowest: compounds 2, 1, 4 and 3 (each within the scatter of the next).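

In this assay, exchanging 2-methoxyphenyl for 4-iodophenyl on the amine nitrogen gives a 1.3-fold higher number from compound 1 to compound 4 (0.11 log units; within the scatter), so compound 4 cannot be separated from compound 1. This is a second exchange at this nitrogen, alongside a 1.6-fold higher number from compound 2 to compound 3 (0.20 log units; within the scatter), and here a group with one hydrogen-bond acceptor leaves and an iodine-bearing group with none enters, yet the number again does not move beyond the scatter. No measurement is available that could give a reason for this result.

All four compounds carry a substituted phenyl ring on this nitrogen, so the compounds shown cannot tell whether a plain butyl chain in place of that ring, or a phenyl ring bearing a carboxylic acid or an amine, would shift the number beyond the scatter. On these data alone, the rest of the shared core is also the same throughout, including its hydroxyl group, so how much the number depends on that part of the structure remains open.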